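The source may hold more compounds than are shown below. What is called first, only, known or untested is meant among the compounds shown, and "the series" means these compounds.

Compound 2 `[N-]=[N+]=NCC(O)Cn1c(=O)n(C2OC(CO)[C@@H](O)[C@H]2O)c2nc(N)nc(O)c21` carries a 2-azido-1-hydroxyethyl group on a saturated chain carbon bound to an aromatic nitrogen. In a functional assay on the whole organism (B cells) with Mus musculus as the target (on this read-out higher numbers stand for larger maximal responses and lower numbers for smaller maximal responses), compound 2 gives 91%. Within the data shown here, the only other measured compound, compound 1 `CCn1c(=O)n(C2OC(CO)[C@@H](O)[C@H]2O)c2nc(N)nc(O)c21`, has methyl in that position and gives 82% in this assay, so the two values sit within the scatter of each other; the one measured step, a number 9 percentage points higher from compound 1 to compound 2 (within the scatter), did not move the read-out beyond the scatter. Compound 3 `Nc1nc(O)c2c(n1)n(C1OC(CO)[C@@H](O)[C@H]1O)c(=O)n2CC(O)CO` differs from compound 2 by hydroxy in place of azido on a saturated chain carbon, two bonds along the chain from an oxygen on a saturated carbon. Among the measured compounds shown here, no measured step exchanges azido for hydroxy, so the expectation can rest only on the small effect seen so far. Because the step of a number 9 percentage points higher from compound 1 to compound 2 (within the scatter) stayed within the scatter, compound 3 is expected to give about the same maximal response, a step of a number 3 percentage points lower from compound 2 to compound 3 (within the scatter). The estimate for compound 3 is 88%, with a range from 74% to 100%.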

Compound 3, largest response reached (reported as maximal response), in percent of the reference or control that the assay uses: 136%
Compound 3: the middle estimate sits 48 percentage points below what was measured, outside the stated range (above it).
By their numbers in this assay, from the lowest: compounds 1 and 2 (each within the scatter of the next); then compound 3.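

In this assay the exchange of azido for hydroxy gives a number 45 percentage points higher from compound 2 to compound 3 (beyond the scatter), so this saturated chain carbon can move the response well beyond the scatter, which the earlier pair did not show. Against the methyl group, the 1,2-dihydroxyethyl group gives a number 54 percentage points higher from compound 1 to compound 3 (beyond the scatter), whereas the 2-azido-1-hydroxyethyl group gives only a number 9 percentage points higher from compound 1 to compound 2 (within the scatter), so among these compounds a longer group alone does not bring the rise, and what stands at that carbon matters. Nothing at hand explains why the hydroxy group has this effect.

On these data alone, whether an amine or a carboxylic acid in place of the hydroxy group would give a similar response remains open. So does the response to a longer chain carrying hydroxy groups.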